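From phenyl to 4-methylphenyl in compound 2

A few compounds are considered here, and "the series" means these few. Any claim that something is new, unique, unknown or untested is made for them only; others in the source may bear on it.

In a functional assay on SGC-7901 cells (Homo sapiens) for cytotoxicity, read by MTT assay, with a stated time of 48 h (on this read-out lower numbers stand for stronger inhibition and higher numbers for weaker inhibition), compound 1 (`CC1=NN(C(=O)c2ccc(C)cc2)C(c2ccccc2O)C1`) gives 51500 nM and compound 2 (`CC1=NN(S(=O)(=O)c2ccccc2)C(c2ccccc2O)C1`) gives 66400 nM so the two values lie within the scatter of each other. Compound 3 (`CC1=NN(S(=O)(=O)c2ccc(C)cc2)C(c2ccccc2O)C1`) carries methyl in place of hydrogen on an aromatic carbon of compound 2, para to a large group (methyl in place of hydrogen on an aromatic carbon). Within the data shown here, no step between measured compounds is available to size this change, and no shift beyond the scatter is expected in either direction. The estimate amounts to a 1.1-fold lower number from compound 2 to compound 3 (0.06 log units; within the scatter) as the expected step. Compound 3 is estimated at 58000 nM with an expected range of 27000 nM to 120000 nM in this assay.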

Compound 3, half-maximal inhibitory concentration: 73600 nM
Compound 3: middle estimate off by 1.3-fold (0.10 log units), on the low side; the range from low to high includes it.
By their numbers in this assay, from the lowest: compounds 1, 2 and 3 (each within the scatter of the next).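

In this assay, among these compounds, phenyl to 4-methylphenyl gives a 1.1-fold higher number from compound 2 to compound 3 (0.04 log units; within the scatter) as the first step that can be sized. At this position, para to a large group, methyl in place of hydrogen therefore causes no shift beyond the scatter. No available evidence gives a reason for this result.

Still open, on these data alone, is whether a different group at the same position, such as an amine, a carboxylic acid or a longer chain, would shift the number beyond the scatter.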